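Chain extension on a weakly cytotoxic sulfonamide

A few compounds are considered here, and "the series" means these few. Any claim that something is new, unique, unknown or untested is made for them only; others in the source may bear on it.

Among the compounds with values here, in a functional assay on MDA-MB-435 cells (Homo sapiens) for cytotoxicity, read by MTT assay, with a stated time of 72 h (a higher number here means a weaker inhibitor, a lower number a stronger inhibitor), compound 1 `N[C@H]1CC[C@H](Nc2c(C(=O)NCc3ccc(Oc4ccccc4)cc3)nc(Br)c3cccnc23)CC1` gives 4000 nM, the only number in the set. Compound 2 `CNc1c(C(=O)NCc2ccc(F)cc2)nc(Br)c2cccnc12` reads > 20000 nM, which is a limit of the assay. Compound 3 `CS(=O)(=O)NCCCN(c1nc(C(=O)NCc2ccc(F)cc2)c(O)c2ncccc12)S(C)(=O)=O` reads > 20000 nM, also a limit, and this is the limit of > 20000 nM in this assay, at which 2 of the 3 values shown sit. Compound 4 `CS(=O)(=O)NCCCCCCN(c1nc(C(=O)NCc2ccc(F)cc2)c(O)c2ncccc12)S(C)(=O)=O` carries 3-(methanesulfonamido)propyl in place of methanesulfonamido on a saturated chain carbon, three bonds along the chain from a sulfonamide nitrogen. Within the data shown here, no measured step in this assay bears on this change. No shift beyond the scatter is expected, in either direction. The estimated a number no higher from compound 3 to compound 4 (the limit leaves the size open) is expected to be small. For compound 4 the expected value is 20000 nM, with an estimated range from 8000 nM to 40000 nM.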

Compound 4, half-maximal inhibitory concentration: 20000 nM
Compound 4: the middle estimate sits on the measured number at the digits printed, and the stated range covers the measured number.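

On the saturated chain carbon, three bonds along the chain from a sulfonamide nitrogen, 3-(methanesulfonamido)propyl in place of methanesulfonamido gives a number no higher from compound 3 to compound 4 (the limit leaves the size open) in this assay. Of the two sulfonamides, only compound 4 gives a number, 20000 nM. The size of the step stays open because compound 3 rests on a limit: the limit of > 20000 nM in this assay, at which 2 of the 4 values shown sit.

On these data alone, whether a still longer chain, or an amine or a carboxylic acid in place of the methanesulfonamido group, would move the number beyond the scatter remains open.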